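The compounds below may be only part of what the source reports. "The series", "measured", "known", "first", "only" and "open" are said of these compounds alone.

Compounds measured so far:
compound 1, `Oc1cccc(-c2cc(-c3cccc(F)c3)cc(-c3ccccc3O)n2)c1`: in a functional assay on T47D cells (Homo sapiens) for inhibition (on this read-out higher numbers stand for weaker inhibition and lower numbers for stronger inhibition), compound 1 gives > 50000 nM, a limit of the assay rather than a number.
compound 2, `Oc1cccc(-c2cc(-c3cccc(F)c3)cc(-c3cccc(O)c3)n2)c1`: in this assay compound 2 gives 21300 nM.

Compound 2 thus holds the only number shown; the other value is a limit (the limit of > 50000 nM in this assay, at which 1 of the 2 values shown sits). Going by the values given here, the one measured step, an at least 2.3-fold lower number from compound 1 to compound 2 (0.37 log units; beyond the scatter), moved a hydroxyphenyl group and so does not touch the part that changes next. Compound 3, `Oc1cccc(-c2cc(-c3ccccc3C(F)(F)F)cc(-c3cccc(O)c3)n2)c1`, differs from compound 2 in that (2-(trifluoromethyl)phenyl in place of 3-fluorophenyl on an aromatic carbon). Among the compounds with values here, with no measured step bearing on this change, the expected step is a 1.2-fold higher number from compound 2 to compound 3 (0.07 log units; within the scatter), not beyond the scatter. Compound 3 is estimated at 25000 nM, between 8000 nM and 80000 nM.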

Compound 3, half-maximal inhibitory concentration: 4350 nM
Compound 3: middle estimate off by 5.7-fold (0.76 log units), on the high side; measured number outside the range, below it.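

In this assay, 2-(trifluoromethyl)phenyl in place of 3-fluorophenyl gives a 4.9-fold lower number from compound 2 to compound 3 (0.69 log units; beyond the scatter), which means stronger inhibition. The aromatic carbon opposite the ring nitrogen therefore affects inhibition, and the entering group, with more heavy atoms than the one it replaces, does not weaken it. Nothing available explains this gain. The substituent and its place on the phenyl ring change together, so the compounds shown do not separate their contributions. From the compounds shown here alone, how an amine or a carboxylic acid on that phenyl ring would read also remains open.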